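The compounds below may be only part of what the source reports. "The series", "measured", "known", "first", "only" and "open" are said of these compounds alone.

Three compounds share one core. Compound 1 `CCOC(=O)C(=O)Nc1cccccc1=O` carries hydrogen on the aromatic carbon in question, and in a functional assay on the whole organism (strain Sprague-Dawley CD) for inhibition, with Rattus norvegicus as the target, read by paw edema, at a dose of 100 mg/kg by the oral route (on this read-out higher numbers stand for a stronger effect at the one dose given and lower numbers for a weaker effect), compound 1 gives 91%. Compound 2 `CCOC(=O)C(=O)Nc1ccccc(Oc2ccccc2)c1=O` carries phenoxy in place of that hydrogen, and in this assay compound 2 gives 9%. Compound 3 `CCOC(=O)C(=O)Nc1ccccc(O)c1=O` carries hydroxy there, and in this assay compound 3 gives 0%. Among these three, compound 2 stands second highest; its nearest neighbour is compound 3, and the two lie within the scatter of each other, while compound 1 lies far higher, as the step of a number 82 percentage points lower from compound 1 to compound 2 (beyond the scatter) shows.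

Compound 4 `CCOC(=O)C(=O)Nc1ccccc(OC)c1=O` differs from compound 2 in one place: methyl in place of phenyl on an oxygen on an aromatic ring. The step that bears most directly on this change is a number 9 percentage points lower from compound 2 to compound 3 (within the scatter), where the same oxygen lost its phenyl and the number did not move beyond the scatter. The steps of a number 82 percentage points lower from compound 1 to compound 2 (beyond the scatter) and a number 91 percentage points lower from compound 1 to compound 3 (beyond the scatter) both show that putting any oxygen group on that aromatic carbon removes nearly all of the effect, whatever sits on the oxygen. The expectation is therefore that compound 4 stays near compound 2, with a step of a number 3 percentage points lower from compound 2 to compound 4 (within the scatter) not beyond the scatter. Compound 4 is estimated at 6%, within the range 0% to 22%.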

Compound 4, a percentage reported as inhibition, in the whole organism at one dose (the size of the read-out at that dose, not a potency): 56%
The estimate for compound 4 lay 50 percentage points below the measured number; the measured number lies above the stated range.
By their numbers in this assay, from the lowest: compounds 3 and 2 (each within the scatter of the next); then compound 4; then compound 1.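

In this assay, the group on the oxygen turns out to matter after all: putting methyl in place of phenyl gives (a number 47 percentage points higher from compound 2 to compound 4 (beyond the scatter)), and putting methyl in place of hydrogen gives (a number 56 percentage points higher from compound 3 to compound 4 (beyond the scatter)), so the closeness of compound 2 and compound 3 does not extend to every group on that oxygen. An oxygen on this aromatic carbon therefore does not by itself remove nearly all of the effect, although methoxy still falls short of hydrogen there, with (a number 35 percentage points lower from compound 1 to compound 4 (beyond the scatter)), and across the three oxygen groups the number does not follow the count of heavy atoms, since methyl stands above both hydrogen and phenyl. Nothing available explains why methoxy parts from hydroxy and phenoxy in this way.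

From the compounds shown here alone, it remains open whether a longer chain on the oxygen, such as ethyl or propyl, would stay near compound 4 or drop towards compound 2, and whether an amine on the same aromatic carbon would behave like methoxy. Since each compound was read at a single dose, the numbers also leave open how compound 1 and compound 4 compare in potency.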